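Swapping the tetrazolylphenyl arm for a small imidazole

The source may hold more compounds than are shown below. What is called first, only, known or untested is meant among the compounds shown, and "the series" means these compounds.

Measured so far:
Compound 1 `Clc1cc(Cl)cc(CO[C@H]2CCCN(Cc3ncco3)[C@H]2c2ccccc2)c1`: in an assay on isolated protein for activation of cGMP-dependent protein kinase 1 (Homo sapiens), read by ADP-Glo, with stated times of 120 min and 40 min (a lower number here means that less compound is needed, a higher number that more compound is needed for the effect), compound 1 gives > 200000 nM, a limit of the assay.
Compound 2 `Clc1cc(Cl)cc(CO[C@H]2CCCN(Cc3ccc(-c4nn[nH]n4)cc3)[C@H]2c2ccccc2)c1`: compound 2 gives 74000 nM.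
Compound 3 `OC[C@@H](O[C@H]1CCCN(Cc2ccc(-c3nn[nH]n3)cc2)[C@H]1c1ccccc1)c1cc(Cl)cc(Cl)c1`: compound 3 gives 131000 nM.

Within the data shown here, compound 2 gives one of only two numbers; compound 3 lies within the scatter of it (a 1.8-fold higher number from compound 2 to compound 3 (0.25 log units; within the scatter)). Compound 1 contributes only a limit (the limit of > 200000 nM in this assay, at which 1 of the 3 values shown sits). Compound 4 `Clc1cc(Cl)cc(CO[C@H]2CCCN(Cc3ncc[nH]3)[C@H]2c2ccccc2)c1` differs from compound 2 by 1H-imidazol-2-yl in place of 4-(2H-tetrazol-5-yl)phenyl on a saturated chain carbon bound to an amine nitrogen in a ring.

The step that bears on this is an at least 2.7-fold lower number from compound 1 to compound 2 (0.43 log units; beyond the scatter), where the 4-(2H-tetrazol-5-yl)phenyl replaced a small five-membered azole. Compound 4 returns to a small azole, so a step to a higher number is expected, a 2.2-fold higher number from compound 2 to compound 4 (0.33 log units; beyond the scatter). Compound 4 is therefore estimated at 160000 nM, within 60000 nM to 450000 nM, with a fair chance that only a limit is reported.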

Compound 4, half-maximal effective concentration: 47000 nM
Compound 4: middle estimate off by 3.4-fold (0.53 log units), on the high side; the measured number lies below the stated range.
By their numbers in this assay, from the lowest: compounds 4, 2 and 3 (each within the scatter of the next, the first and the last beyond it). At a limit, above all of these: compound 1.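

In this assay, the earlier gain over compound 1 does not depend on the 4-(2H-tetrazol-5-yl)phenyl, since a 1.6-fold lower number from compound 2 to compound 4 (0.20 log units; within the scatter), with the smaller 1H-imidazol-2-yl entering at this place. Small azoles here are not interchangeable, as an at least 4.2-fold lower number from compound 1 to compound 4 (0.62 log units; beyond the scatter), with 1H-imidazol-2-yl in place of 1,3-oxazol-2-yl. That step has only a lower bound, and compound 1 stands at a limit: the limit of > 200000 nM in this assay, at which 1 of the 4 values shown sits. Open, going by these compounds, is whether the hydroxymethyl of compound 3 would behave alike with 1H-imidazol-2-yl in place. Also open, on these data alone, is how a carboxylic acid or a primary amine would read at this place.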